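This account rests on a few compounds, and the source may have more. Where it says the series, first, only, none or still open, it means among the compounds named here.

Measured so far:
- compound 1 `Nc1ccccc1NC(=O)c1ccc(CNc2nc3ccc(Br)cc3s2)cc1`: 400 nM
- compound 2 `Nc1ccccc1NC(=O)c1ccc(CNc2nc3ccccc3[nH]2)cc1`: 300 nM
- compound 3 `Nc1ccccc1NC(=O)c1ccc(CSc2nc3ccc(NCc4ccccn4)cc3s2)cc1`: 1000 nM

All three values come from a functional assay on HCT-116 cells (Homo sapiens) for cytotoxicity, read by MTT assay; on this read-out lower numbers stand for stronger inhibition and higher numbers for weaker inhibition. Compound 3 has the highest number of the three, and its distance from each of the other two lies beyond the scatter. Compound 1 and compound 2 lie within the scatter of each other.

The next compound is compound 4 `Nc1ccccc1NC(=O)c1ccc(CSc2nc3ccccc3s2)cc1`, reached from compound 3 by one change: hydrogen in place of ((pyridin-2-yl)methyl)amino on an aromatic carbon. In words, hydrogen stands in place of ((pyridin-2-yl)methyl)amino on an aromatic carbon of a six-membered aromatic ring of carbon only, part of a fused or bridged system of two rings.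

Among the measured compounds shown here, no pair of measured compounds differs in one place, so the size of this change has no direct precedent. For the measured compounds named here, the only guide is indirect: compound 1 at 400 nM and compound 2 at 300 nM both lack the departing group, although they also differ from compound 3 elsewhere. A modest move to a lower number in this assay is therefore expected, and a result within the scatter would not be surprising. The expected change is a 2.0-fold lower number from compound 3 to compound 4 (0.30 log units; within the scatter). For compound 4 the estimated value is 500 nM, with an expected range from 150 nM to 1500 nM.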

Compound 4, half-maximal inhibitory concentration: 800 nM
Beside the measured number, compound 4's estimate is 1.6-fold (0.20 log units) below it; low and high end bracket the measured number.
By their numbers in this assay, from the lowest: compounds 2, 1, 4 and 3 (each within the scatter of the next, the first and the last beyond it).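

In this assay, among the compounds shown here, the first comparison that differs in one place gives a 1.3-fold lower number from compound 3 to compound 4 (0.10 log units; within the scatter), which lies within the scatter. On this aromatic carbon of the six-membered aromatic ring of carbon only, the whole ((pyridin-2-yl)methyl)amino group, with its pyridine ring, its hydrogen-bond donor and its hydrogen-bond acceptors, can thus be exchanged for hydrogen without separating compound 3 from compound 4 on this read-out. No independent measurement bears on this result, and the step stands as an observation only.

For the compounds shown here, open is whether this insensitivity holds for other groups on the same carbon, such as a methoxy group, a fluorine, a carboxylic acid or a longer chain ending in a primary amine, since one exchange describes only this pair. Compound 1 and compound 2 carry an amine link where compound 4 carries a sulfur link, but both also differ from compound 4 elsewhere, so the contribution of the link on its own cannot yet be read.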